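Acetamido for trifluoromethyl: a first step in the series

The source may report more compounds than this note shows. Statements on the series, on what has been measured and on what is new or still open speak of the compounds shown alone.

Among the compounds with values here, in a functional assay on SMMC-7721 cells (Homo sapiens) for cytotoxicity, read by MTT assay, with a stated time of 24 h (on this read-out lower numbers stand for stronger inhibition and higher numbers for weaker inhibition), only two compounds have values so far. Compound 1 `COc1cc(/C=C2\CN(C)C/C(=C\c3ccncc3)C2=O)cc(OC)c1OC` gives 9130 nM in this test, and compound 2 `O=C1/C(=C/c2cccnc2)CN(S(=O)(=O)c2ccc(C(F)(F)F)cc2)C/C1=C\c1ccccc1F` gives 7900 nM in the same test. These two values lie within the scatter of each other, so compound 2 stands level with compound 1. Compound 3 `CC(=O)Nc1ccc(S(=O)(=O)N2C/C(=C\c3cccnc3)C(=O)/C(=C/c3ccccc3F)C2)cc1` has acetamido in place of trifluoromethyl on an aromatic carbon, para to a large group (acetamido in place of trifluoromethyl on an aromatic carbon). Within the data shown here, no measured pair isolates a single change, so the data give neither the size nor the direction of this one. In this assay no step beyond the scatter is expected, and the expected step of a 1.1-fold higher number from compound 2 to compound 3 (0.06 log units; within the scatter) is small. For compound 3 the estimated value is 9000 nM with an expected range of 4000 nM to 20000 nM in this test.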

Compound 3, half-maximal inhibitory concentration: 10900 nM
Beside the measured number, compound 3's estimate is 1.2-fold (0.08 log units) below it; the measured number falls inside the stated range.
By their numbers in this assay, from the lowest: compounds 2, 1 and 3 (each within the scatter of the next).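

In this assay the series now has its first pair that differs in one place, and acetamido in place of trifluoromethyl gives a 1.4-fold higher number from compound 2 to compound 3 (0.14 log units; within the scatter). On an aromatic carbon, para to a large group, the two groups therefore stand level, although acetamido brings a hydrogen-bond donor and a hydrogen-bond acceptor that trifluoromethyl lacks. This single pair shows that the read-out can stay level across this exchange, but it sets no trend for the position. Within the data shown here, nothing measured so far bears on why these two groups read alike.

On these data alone, whether an amine, a carboxylic acid or a longer chain at this place would also stay level remains open. So does whether the same exchange would read alike on the core of compound 1, whose other parts differ.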